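Triazole substituent changes on a shared butenolide-derived core

The compounds below may be only part of what the source reports. "The series", "measured", "known", "first", "only" and "open" are said of these compounds alone.

Measured so far:
compound 1, `Cc1ccc(S(=O)(=O)NCc2cn(C[C@H](O)[C@H]3OC(=O)C(OCc4ccccc4)=C3OCc3ccccc3)nn2)cc1`, 68000 nM
compound 2, `O=C1O[C@H]([C@@H](O)Cn2cc(-c3cccc(O)c3)nn2)C(OCc2ccccc2)=C1OCc1ccccc1`, 54100 nM
compound 3, `C[Si](C)(C)c1cn(C[C@H](O)[C@H]2OC(=O)C(OCc3ccccc3)=C2OCc2ccccc2)nn1`, 52600 nM

All three compounds share one core and differ only in one group on that shared core. Within the data shown here, in a functional assay on CFPAC-1 cells (Homo sapiens) for antiproliferative activity, read by MTT assay, with a stated time of 72 h (a lower number here means a stronger inhibitor, a higher number a weaker inhibitor), compound 3 gives the lowest of the three numbers, but a 1.0-fold lower number from compound 2 to compound 3 (0.01 log units; within the scatter) and a 1.3-fold lower number from compound 1 to compound 3 (0.11 log units; within the scatter) both lie within the scatter, so no compound can be called stronger or weaker than another on these data.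

Compound 4, `Cc1ccc(-c2cn(C[C@H](O)[C@H]3OC(=O)C(OCc4ccccc4)=C3OCc3ccccc3)nn2)cc1`, is not yet measured. It differs from compound 3 by a group of 7 heavy atoms (7 carbon; one six-membered aromatic ring of carbon only) in place of a group of 4 heavy atoms (3 carbon, 1 silicon; no ring), on an aromatic carbon.

The step that bears most directly on this is a 1.0-fold lower number from compound 2 to compound 3 (0.01 log units; within the scatter), where a six-membered aromatic ring of carbon only was likewise exchanged against the silicon-bearing group and the number hardly moved. The step of a 1.3-fold lower number from compound 1 to compound 3 (0.11 log units; within the scatter), with a larger group removed, also stayed within the scatter. On this basis no step beyond the scatter is expected in this assay for compound 4; the expected step of a 1.0-fold higher number from compound 3 to compound 4 (0.02 log units; within the scatter) is small, with the number for compound 4 estimated at 55000 nM, in the range 25000 nM to 120000 nM.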

Compound 4, half-maximal inhibitory concentration: > 100000 nM
Compound 4: only a limit was reported; the forecaster's own chance of this, stated with the estimate: 10%; middle value at least 1.8-fold (0.25 log units) away from the limit.
By their numbers in this assay, from the lowest: compounds 3, 2 and 1 (each within the scatter of the next). At a limit, above all of these: compound 4.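

In this assay, among these compounds, compound 4 is the first entry without a number, and it is reported only as a limit: the limit of > 100000 nM in this assay, at which 1 of the 4 values shown sits. This gives floors rather than sizes for an at least 1.9-fold higher number from compound 3 to compound 4 (0.27 log units; that floor lies within the scatter), for an at least 1.8-fold higher number from compound 2 to compound 4 (0.26 log units; that floor lies within the scatter) and for an at least 1.4-fold higher number from compound 1 to compound 4 (0.16 log units; that floor lies within the scatter); each floor lies within the scatter, so 4-methylphenyl on this aromatic carbon cannot be separated from the other three groups, though the true steps may be larger. Among the compounds shown here, the pair of compounds 2 and 4 adds the first comparison of two phenyl-bearing groups at this position, and it remains unresolved.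

Open, from the compounds shown here alone, is whether any group on this aromatic carbon gives a number clearly apart from those of compounds 1, 2 and 3. Also open, going by these compounds, is how an amine, a carboxylic acid or a longer alkyl chain there would read in this assay.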